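The source may hold more compounds than are shown below. What is called first, only, known or untested is meant among the compounds shown, and "the series" means these compounds.

Working notes on the series. In an assay on T-REx-293 cells for inhibition of potassium channel subfamily T member 1 (Homo sapiens), read by patch clamp (on this read-out lower numbers stand for stronger inhibition and higher numbers for weaker inhibition), compound 1 `C[C@H](NC(=O)c1cc(C(F)(F)F)nn1C)c1nc(-c2cccc(F)c2)no1` gives 136 nM, compound 2 `Cc1cc(-c2noc([C@H](C)NC(=O)c3cc(C(F)(F)F)nn3C)n2)ccn1` gives 165 nM, and compound 3 `COc1cc(-c2noc([C@H](C)NC(=O)c3cc(C(F)(F)F)nn3C)n2)ccn1` gives 27 nM, the lowest of the three numbers. Two steps lie beyond the scatter: a 5.0-fold lower number from compound 1 to compound 3 (0.70 log units; beyond the scatter) and a 6.1-fold lower number from compound 2 to compound 3 (0.79 log units; beyond the scatter); by contrast a 1.2-fold higher number from compound 1 to compound 2 (0.08 log units; within the scatter). Compound 4 `C[C@H](NC(=O)c1cc(C(F)(F)F)nn1C)c1nc(-c2ccnc(N(C)C)c2)no1` carries dimethylamino in place of methoxy on an aromatic carbon. Only the exchange of methyl for methoxy on the same aromatic carbon bears on this change, and it was modest, so swapping one small group for another there is expected to shift this assay by no more than that, and possibly not beyond the scatter. Compound 4 is expected near 45 nM, with a range of 15 nM to 135 nM. That estimate amounts to a 1.7-fold higher number from compound 3 to compound 4 (0.22 log units; within the scatter).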

Compound 4, half-maximal inhibitory concentration: 454 nM
Compound 4: middle estimate off by 10-fold (1.00 log units), on the low side, and the stated range ends below it.
By their numbers in this assay, from the lowest: compound 3; then compounds 1 and 2 (each within the scatter of the next); then compound 4.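

In this assay the 2-(dimethylamino)pyridin-4-yl group gives the highest number at this place: dimethylamino loses much more against methoxy (a 17-fold higher number from compound 3 to compound 4 (1.23 log units; beyond the scatter)) than against methyl (a 2.8-fold higher number from compound 2 to compound 4 (0.44 log units; beyond the scatter)), and the change from 3-fluorophenyl also raises the number (a 3.3-fold higher number from compound 1 to compound 4 (0.52 log units; beyond the scatter)). This aromatic carbon next to the ring nitrogen therefore does not treat small groups alike: methoxy and dimethylamino, each with one hydrogen-bond acceptor and no donor, stand at opposite ends of the four compounds. Nothing available accounts for the size of this step. On these data alone, whether a primary amine, a methylamino or an ethoxy group here would stay near methoxy or move toward dimethylamino remains open.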